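A few compounds are considered here, and "the series" means these few. Any claim that something is new, unique, unknown or untested is made for them only; others in the source may bear on it.

Measured so far in an assay on mitochondria (strain BALB/c) for inhibition of glycerol-3-phosphate acyltransferase 1, mitochondrial (Mus musculus), read by scintillation counting, with a stated time of 10 min; on this read-out lower numbers stand for stronger inhibition and higher numbers for weaker inhibition:
compound 1 `CCCCCCCCS(=O)(=O)Nc1ccc(-c2ccccc2Cl)cc1C(=O)O` gives 14400 nM.
compound 2 `CCCCCCCCS(=O)(=O)Nc1ccc(-c2cccc(Cl)c2)cc1C(=O)O` gives 8900 nM.

Within the data shown here, compound 1 has the highest number of the two; the only step to it is a 1.6-fold lower number from compound 1 to compound 2 (0.21 log units; within the scatter), which lies within the scatter.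

Compound 3 `CCCCCCCCS(=O)(=O)Nc1ccc(-c2ccccc2-c2ccccc2)cc1C(=O)O` differs from compound 1 by phenyl in place of chloro on an aromatic carbon. Among the measured compounds shown here, no measured step bears on this change; the one step known, from compound 1 to compound 2, moves a chlorine around its ring and stays within the scatter, so nothing here points to a move beyond it. The estimated step is therefore a 1.2-fold lower number from compound 1 to compound 3 (0.08 log units; within the scatter). Compound 3 is expected at 12000 nM in this assay, with a range from 4000 nM to 40000 nM.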

Compound 3, half-maximal inhibitory concentration: 10100 nM
The estimate for compound 3 lay 1.2-fold (0.07 log units) above the measured number, and the stated range covers the measured number.
By their numbers in this assay, from the lowest: compounds 2, 3 and 1 (each within the scatter of the next).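

In this assay, phenyl, with its six-membered aromatic ring, in place of chloro at this place, ortho to a large group, gives a 1.4-fold lower number from compound 1 to compound 3 (0.15 log units; within the scatter). A far larger group than a single chlorine therefore leaves the number within the scatter, so the read-out at this position does not separate these two groups. No measurement on hand accounts for this result.

As far as these compounds go, whether an amine or a carboxylic acid at this place would give a step beyond the scatter stays open. So does the effect of a longer chain on the sulfonyl group.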